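Chloro for methoxy on the benzyl ring of compound 1

A few compounds are considered here, and "the series" means these few. Any claim that something is new, unique, unknown or untested is made for them only; others in the source may bear on it.

Measured compounds:
compound 1 `CNc1nc(-c2cn(Cc3cccc(OC)c3)nn2)nc2c1ncn2[C@@H]1O[C@H](CO)[C@@H](O)[C@H]1O` gives 957 nM
compound 2 `CCCCc1cn(-c2nc(NC)c3ncn([C@@H]4O[C@H](C(=O)NCC)[C@@H](O)[C@H]4O)c3n2)nn1` gives 750 nM
compound 3 `CCCCc1cn(-c2nc(NC)c3ncn([C@@H]4O[C@H](CO)[C@@H](O)[C@H]4O)c3n2)nn1` gives 848 nM

All three were tested in an assay on CHO cells for displacement of a labelled ligand from adenosine receptor A1 (Homo sapiens); a higher number here means a weaker inhibitor, a lower number a stronger inhibitor. The number for compound 1 lies within the usual scatter of both compound 3 and compound 2, so the three values cannot be told apart. For the measured compounds named here, the one step between measured compounds that differ in a single place, a 1.1-fold higher number from compound 2 to compound 3 (0.05 log units; within the scatter), concerns the sugar side of the shared core and not the benzyl ring.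

Compound 4 `CNc1nc(-c2cn(Cc3cccc(Cl)c3)nn2)nc2c1ncn2[C@@H]1O[C@H](CO)[C@@H](O)[C@H]1O` differs from compound 1 only at the benzyl ring: chloro in place of methoxy on an aromatic carbon. Going by the values given here, no measured pair shows a change at this ring, so the step has no direct precedent. Without such a precedent, the estimate for compound 4 in this assay is 800 nM, with a range from 250 nM to 2500 nM. The expected step is a 1.2-fold lower number from compound 1 to compound 4 (0.08 log units; within the scatter), which does not go beyond the scatter.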

Compound 4, inhibition constant: 956 nM
For compound 4 the middle estimate is 1.2-fold (0.08 log units) below the measured one; the range from low to high includes it.
By their numbers in this assay, from the lowest: compounds 2, 3, 4 and 1 (each within the scatter of the next).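

Among the compounds shown, this is the only pair that differs at the benzyl ring, and in this assay chloro in place of methoxy gives a 1.0-fold lower number from compound 1 to compound 4 (0.00 log units; within the scatter) and stays within the usual scatter. At this position on the six-membered aromatic ring, then, the assay does not tell the two groups apart, even though chloro has one heavy atom and no hydrogen-bond acceptor, while methoxy has two heavy atoms and one hydrogen-bond acceptor. No measurement at hand explains why the two groups read alike.

One pair cannot show whether any group at this place would give a similar number, so an amine, a carboxylic acid or a longer chain there remains an open case. Also open, going by these compounds, is whether the same change would read alike with ethylcarbamoyl in place of hydroxymethyl on the sugar side.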